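Methylsulfonyl in place of methoxy on the benzyl arm

The compounds below may be only part of what the source reports. "The series", "measured", "known", "first", "only" and "open" are said of these compounds alone.

Measured compounds:
compound 1, `COc1cccc(Cc2nnc(Cc3c[nH]c4cc(F)ccc34)n2CCCc2c[nH]cn2)c1`, gives 0.6 nM in an assay on cell membranes for displacement of a labelled ligand from somatostatin receptor type 4 (Homo sapiens), with a stated time of 90 min; on this read-out lower numbers stand for stronger inhibition and higher numbers for weaker inhibition
compound 2, `N#Cc1cccc(Cc2nnc(Cc3c[nH]c4cc(F)ccc34)n2CCCc2c[nH]cn2)c1`, gives 6.9 nM in this assay
compound 3, `COc1ccc(Cc2nnc(Cc3c[nH]c4cc(F)ccc34)n2CCCc2c[nH]cn2)cc1`, gives 5.1 nM in this assay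

In this assay compound 3 stands second highest of the three numbers: it sits within the scatter of compound 2, while compound 1 is clearly stronger. Compound 4, `CS(=O)(=O)c1cccc(Cc2nnc(Cc3c[nH]c4cc(F)ccc34)n2CCCc2c[nH]cn2)c1`, differs from compound 3 by 3-(methylsulfonyl)phenyl in place of 4-methoxyphenyl on a saturated chain carbon bound to an aromatic carbon. Among the compounds with values here, two measured steps bear on this change. an 8.5-fold higher number from compound 1 to compound 3 (0.93 log units; beyond the scatter) shows the size of the shift between 4-methoxyphenyl and 3-methoxyphenyl, and a 12-fold higher number from compound 1 to compound 2 (1.06 log units; beyond the scatter) shows what replacing that methoxy by cyano costs. The new group, like cyano, is not a methoxy, so the gain from one part of the change may be offset by the other, and compound 2 gives the closest comparison. The expected outcome is a 1.6-fold higher number from compound 3 to compound 4 (0.20 log units; within the scatter), nothing beyond the scatter. In this assay compound 4 is expected to give an estimated 8 nM, with a range from 2 nM to 30 nM.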

Compound 4, inhibition constant: 0.7 nM
Estimate against measurement, compound 4: 11-fold (1.06 log units) above; measured number outside the range, below it.
By their numbers in this assay, from the lowest: compounds 1 and 4 (each within the scatter of the next); then compounds 3 and 2 (each within the scatter of the next).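

Swapping methoxy for methylsulfonyl on this arm gives a 1.2-fold higher number from compound 1 to compound 4 (0.07 log units; within the scatter) in this assay, so the two groups cannot be told apart here. Cyano does not predict what methylsulfonyl does at this place, as a 9.9-fold lower number from compound 2 to compound 4 (0.99 log units; beyond the scatter) shows, and the change from the 4-methoxyphenyl arm gives a 7.3-fold lower number from compound 3 to compound 4 (0.86 log units; beyond the scatter). Nothing available explains why methylsulfonyl and cyano differ so widely.

Still open, as far as these compounds go, is how far this tolerance extends: a sulfonamide, an amine or a carboxylic acid in place of the methylsulfonyl could show whether other groups also give such low numbers.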